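A few compounds are considered here, and "the series" means these few. Any claim that something is new, unique, unknown or untested is made for them only; others in the source may bear on it.

Measured in an ADME assay on HEK293 cells (Homo sapiens) for cytotoxicity; on this read-out lower numbers stand for stronger inhibition and higher numbers for weaker inhibition:
- compound 1, `CCCCCCCCCCCCCCNC(=O)[C@H](CO)/N=C/c1cccc(OC)c1`: 77300 nM
- compound 2, `CCCCCCCCCCCCCCNC(=O)[C@H](CO)/N=C/c1ccc(OC)cc1`: 81700 nM
- compound 3, `CCCCCCCCCCCCCCNC(=O)[C@H](CO)/N=C/c1ccccc1OC`: 79200 nM

The three measured compounds share one core and differ only in where the methoxy group sits on the aromatic ring. The steps among them are all small: a 1.1-fold higher number from compound 1 to compound 2 (0.02 log units; within the scatter), a 1.0-fold higher number from compound 1 to compound 3 (0.01 log units; within the scatter) and a 1.0-fold lower number from compound 2 to compound 3 (0.01 log units; within the scatter). Compound 3 gives the second highest of the three numbers, with compound 1 nearest and compound 2 furthest, and none of these gaps exceeds the scatter. On this assay the series reads as flat.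

Compound 4, `CCCCCCCCCCCCCCNC(=O)[C@H](CO)/N=C/c1ccccc1O`, is the next compound to be measured. It differs from compound 3 in one place: hydrogen in place of methyl on an oxygen on an aromatic ring. Cut one bond further out this reads as methoxy to hydroxy, so 2-methoxyphenyl becomes 2-hydroxyphenyl.

Among the compounds with values here, none of the measured steps touches this change; they only move the methoxy group around the ring and they all stay within the scatter. Within the data shown here, there is therefore no step in the data from which to read a direction. With the series flat so far, compound 4 is expected to sit close to compound 3, with the expected step of a 1.0-fold higher number from compound 3 to compound 4 (0.00 log units; within the scatter) lying within the scatter, and the range kept wide for want of a guiding step. The estimate for compound 4 in this assay is 80000 nM, between 35000 nM and 180000 nM.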

Compound 4, half-maximal inhibitory concentration: 80800 nM
The estimate for compound 4 lay 1.0-fold (0.00 log units) below the measured number; low and high end bracket the measured number.
By their numbers in this assay, from the lowest: compounds 1, 3, 4 and 2 (each within the scatter of the next).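

Within the data shown here, on this assay the change from methoxy to hydroxy, 2-methoxyphenyl to 2-hydroxyphenyl, gives a 1.0-fold higher number from compound 3 to compound 4 (0.01 log units; within the scatter) and is the first step that alters the group on the oxygen itself rather than its place on the ring. The two steps that alter both the group and its place, a 1.0-fold lower number from compound 2 to compound 4 (0.00 log units; within the scatter) and a 1.0-fold higher number from compound 1 to compound 4 (0.02 log units; within the scatter), are just as small, so the flat reading now covers removal of the methyl as well as movement of the methoxy group, and the four compounds carry no order among them on this read-out. Nothing available bears on why the number stays put when the methyl leaves this oxygen.

Still open, going by these compounds, is whether a different group at this place on the aromatic ring, such as an amine or a carboxylic acid, would leave the number as flat, and whether hydroxy at the other two ring places seen for methoxy would read the same. The long chain on the amide is common to all four compounds, so the effect of a shorter chain on this read-out also remains an open question.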